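Swapping the anisidine ring of compound 2 for a methoxypyridine

A few compounds are considered here, and "the series" means these few. Any claim that something is new, unique, unknown or untested is made for them only; others in the source may bear on it.

Measured so far:
Compound 1, `COc1ccc(Nc2nc(Oc3cccc(NC(=O)C=C(C)C)c3)c3sccc3n2)cc1`: 17600 nM
Compound 2, `COc1ccc(Nc2nc(Oc3cccc(NC(=O)/C=C/C(C)C)c3)c3sccc3n2)cc1`: 25200 nM

Both numbers come from a functional assay on A-431 cells (Homo sapiens) for inhibition, read by MTT assay, with a stated time of 72 h; a higher number here means a weaker inhibitor, a lower number a stronger inhibitor. Compound 2 has the highest of the two numbers shown, but its nearest neighbour, compound 1, sits within the scatter of it: a 1.4-fold higher number from compound 1 to compound 2 (0.16 log units; within the scatter). So the two measured compounds cannot be told apart.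

Compound 3, `COc1ccc(Nc2nc(Oc3cccc(NC(=O)/C=C/C(C)C)c3)c3sccc3n2)cn1`, differs from compound 2 in one place: 6-methoxypyridin-3-yl in place of 4-methoxyphenyl on a nitrogen on an aromatic ring. For the measured compounds named here, this part of the molecule is untouched by the only measured step, which alters the group on the carbonyl carbon and stays within the scatter. Going by the values given here, no measured step therefore bears directly on the change from compound 2 to compound 3, and there is nothing in the numbers that points to a direction.

The expected step is accordingly small: a 1.0-fold lower number from compound 2 to compound 3 (0.00 log units; within the scatter) is the estimate, with no change beyond the scatter. Compound 3 is estimated to give 25000 nM in this assay, with a range from 8000 nM to 80000 nM that allows for the lack of any guiding step.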

Compound 3, half-maximal inhibitory concentration: > 50000 nM
Compound 3: no number, only a limit; the forecaster's own chance of this, stated with the estimate: 15%; middle value at least 2.0-fold (0.30 log units) away from the limit.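

In this assay compound 3 gives > 50000 nM, which is a limit of the assay and not a number. This is the first change shown to the group on the nitrogen, since the earlier pair differed only in the group on the carbonyl carbon, and placing 6-methoxypyridin-3-yl there instead of 4-methoxyphenyl gives an at least 1.9-fold higher number from compound 2 to compound 3 (0.29 log units; that floor lies within the scatter). The swap of this carbon-only ring for a ring with one hetero atom therefore gives no sign of a stronger inhibitor, and its size stays a floor, not a measured step, because the reading ends at the limit: the limit of > 50000 nM in this assay, at which 1 of the 3 values shown sits.

From the compounds shown here alone, how far the true value of compound 3 lies past that limit stays open, so the floor cannot show whether this swap has any real effect on the number. Also open, going by these compounds, is whether a different group on this nitrogen, such as a phenyl ring carrying an amine or a carboxylic acid, would give a lower number, and whether 6-methoxypyridin-3-yl would read the same alongside the 2-methylprop-1-en-1-yl group of compound 1.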